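This account rests on a few compounds, and the source may have more. Where it says the series, first, only, none or still open, it means among the compounds named here.

Compound 1 `O=C(c1ccncc1)N1N=C(c2cc3ccccc3o2)CC1c1ccccc1O` was tested in an ADME assay on Vero cells (Chlorocebus sabaeus) for cytotoxicity, read by MTT assay, with a stated time of 72 h; on this read-out higher numbers stand for weaker inhibition and lower numbers for stronger inhibition. For compound 1 the result is only a limit of the assay, > 195000 nM, not a number. Compound 2 `COc1ccc(C2CC(c3cc4ccccc4o3)=NN2C(=O)c2ccncc2)c(O)c1` likewise reaches only a limit in this assay, > 190000 nM. Compound 3 `CCn1cc(C(=O)N2N=C(c3cc4ccccc4o3)CC2c2ccc(OC)cc2)c(=O)c2ccc(C)nc21` also stops at a limit in this assay, > 156000 nM. Compound 2 and compound 1 differ in one place, (hydrogen in place of methoxy on an aromatic carbon); in this assay the result is a step that the two limits leave unreadable from compound 2 to compound 1, and the two limits the limit of > 190000 nM in this assay, at which 1 of the 3 values shown sits, and the limit of > 195000 nM in this assay, at which 1 of the 3 values shown sits, leave its size unreadable. Compound 4 `CCn1cc(C(=O)N2N=C(c3cc4ccccc4o3)CC2c2ccccc2)c(=O)c2ccc(C)nc21` has not been measured; it differs from compound 3 by hydrogen in place of methoxy on an aromatic carbon. Among the compounds with values here, this is the same kind of change as the one between compound 2 and compound 1, though in that pair the place was also meta to a hydroxy group, which compound 3 lacks. How the core of compound 3 differs from the core of compound 2 is not broken down here. Compound 3 sits at the limit (the limit of > 156000 nM in this assay, at which 1 of the 3 values shown sits), and the earlier step is unreadable. The step from compound 3 to compound 4 is therefore expected to be a step that the limit leaves unreadable from compound 3 to compound 4. Compound 4 is estimated at 200000 nM in this assay, between 100000 nM and 400000 nM, most likely again as a limit.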

Compound 4, half-maximal inhibitory concentration: > 210000 nM
Compound 4 ended at the assay's limit (the forecaster's own chance of this, stated with the estimate: 85%); at least 1.0-fold (0.02 log units) between middle value and limit.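

In this assay compound 3 and compound 4 both end at a limit rather than a number, so the step between them, 4-methoxyphenyl to phenyl, cannot be read. The compounds shown leave open the concentration at which any of them would reach half-maximal inhibition, and whether the methoxy group shifts that concentration at all.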